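Methoxy for chloro on the terminal aryl ring

The source may report more compounds than this note shows. Statements on the series, on what has been measured and on what is new or still open speak of the compounds shown alone.

Measured so far:
compound 1 `COc1ccc(-c2ccc(-c3ccc(C(=N)N)cc3)s2)cc1`: 1240 nM
compound 2 `N=C(N)c1ccc(-c2ccc(-c3ccc(Cl)cc3)s2)cc1F`: 386 nM
compound 3 `COc1cc(OC)cc(-c2ccc(-c3ccc(C(=N)N)c(F)c3)s2)c1`: 502 nM

In a functional assay on NCI-H322M cells (Homo sapiens) for inhibition, read by sulforhodamine B assay, with a stated time of 48 h (on this read-out lower numbers stand for stronger inhibition of growth and higher numbers for weaker inhibition of growth), compound 2 gives the lowest number of the three. Its gap to compound 3 is within the scatter, so no order between these two is claimed; its gap to compound 1 lies beyond the scatter. Compound 4 `COc1ccc(-c2ccc(-c3ccc(C(=N)N)c(F)c3)s2)cc1` is not yet measured. It differs from compound 2 by methoxy in place of chloro on an aromatic carbon. Within the data shown here, no measured pair shows this same change alone, so no step size is known for it. A modest rise is expected for compound 4, judged against compound 1 and its value 1240 nM, which carries methoxy without the fluoro, and against compound 3 with 502 nM. For compound 4 the expected step is a 1.6-fold higher number from compound 2 to compound 4 (0.21 log units; within the scatter). Compound 4 is estimated at 620 nM, in the range 300 nM to 1400 nM.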

Compound 4, concentration for 50% growth inhibition: 3580 nM
Beside the measured number, compound 4's estimate is 5.8-fold (0.76 log units) below it; the measured number lies above the stated range.
By their numbers in this assay, from the lowest: compounds 2 and 3 (each within the scatter of the next); then compound 1; then compound 4.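

In this assay, among these compounds, methoxy in place of chloro on an aromatic carbon para to a large group gives a 9.3-fold higher number from compound 2 to compound 4 (0.97 log units; beyond the scatter) and is the first measured reading of this change at this position. With methoxy held constant, fluoro in place of hydrogen gives a 2.9-fold higher number from compound 1 to compound 4 (0.46 log units; beyond the scatter) so in this pair the fluoro brings no gain. No measurement here accounts for either step.

Open, as far as these compounds go, is whether fluoro in place of hydrogen moves the number the same way when chloro replaces methoxy. Also open, from the compounds shown here alone, is whether methyl or trifluoromethyl at this position would stand nearer chloro or methoxy.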